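Methyl replaces hydrogen on the core of compound 2

The source may hold more compounds than are shown below. What is called first, only, known or untested is meant among the compounds shown, and "the series" means these compounds.

Measured so far:
compound 1 `Nc1nc(N)c2c(Cl)c(NC(=O)CCc3ccc(Cl)cc3)ccc2n1`, in an assay for inhibition of Dihydrofolate reductase (Homo sapiens) (a higher number here means a more potent compound, by a factor of ten per unit of this negative logarithm, a lower number a less potent compound), compound 1 gives 7.44
compound 2 `Nc1nc(N)c2cc(NC(=O)CCc3ccc(Cl)cc3)ccc2n1`, in this assay compound 2 gives 7.33

Compound 2 carries the lowest of the two numbers; its nearest neighbour is compound 1, and the step of a number 0.11 log units lower from compound 1 to compound 2 (within the scatter) lies within the scatter, so the two are not ordered. The unmeasured compound 3 `Cc1c(NC(=O)CCc2ccc(Cl)cc2)ccc2nc(N)nc(N)c12` differs from compound 2 by methyl in place of hydrogen on an aromatic carbon. Going by the values given here, the one measured step that bears on this change is a number 0.11 log units lower from compound 1 to compound 2 (within the scatter), in which chloro gave way to hydrogen on an aromatic carbon of the shared core without a shift beyond the scatter. A single-carbon group entering at an aromatic carbon of the core is therefore expected to give only a small step in this assay, with no direction beyond the scatter. Compound 3 is expected to give 7.45 in this assay, between 7 and 7.9. The expected step is a number 0.12 log units higher from compound 2 to compound 3 (within the scatter).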

Compound 3, logarithm of the reciprocal of the active concentration, log(1/C): 7.48
Compound 3: the middle estimate sits 0.03 log units below what was measured; low and high end bracket the measured number.
By their numbers in this assay, from the lowest: compounds 2, 1 and 3 (each within the scatter of the next).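

With methyl in place of hydrogen on this aromatic carbon, ortho to a large group, this assay gives a number 0.15 log units higher from compound 2 to compound 3 (within the scatter). The change from chloro to methyl at the same carbon gives a number 0.04 log units higher from compound 1 to compound 3 (within the scatter), so a second substituent now stands beside chloro, and hydrogen, chloro and methyl at this carbon of the shared core cannot be told apart in this assay. No supporting measurement is available to explain this lack of separation.

Whether any group at this carbon moves the number beyond the scatter remains open, since an amine, a carboxylic acid or a longer chain such as propyl would test this beyond the three substituents shown. The compounds also leave open whether the same lack of separation would hold at any other carbon of the core.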